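The source may report more compounds than this note shows. Statements on the series, on what has been measured and on what is new or still open speak of the compounds shown alone.

Of the compounds shown here, three sharing one core have been measured in a functional assay on the whole organism with Homo sapiens as the target; on this read-out higher numbers stand for an effect only at larger amounts of compound and lower numbers for an effect already at smaller amounts. In this assay, compound 1 `CC(O)(C(=O)Nc1ccccc1Cl)C(F)(F)F` gives 5400 nM, compound 2 `CC(O)(C(=O)Nc1cccc(C(=O)c2ccccc2)c1)C(F)(F)F` gives 10000 nM and compound 3 `CC(O)(C(=O)Nc1ccc(C(=O)c2ccccc2)cc1Cl)C(F)(F)F` gives 30000 nM. Compound 3 therefore has the highest number of the three, and its gaps to both others lie beyond the scatter.

Compound 4 `CCCCCCNC(=O)c1ccc(NC(=O)C(C)(O)C(F)(F)F)c(Cl)c1` differs from compound 3 in one place, with hexylamino in place of phenyl on a carbonyl carbon. Among the compounds with values here, no measured step makes this exact swap. The closest evidence is a 5.6-fold higher number from compound 1 to compound 3 (0.74 log units; beyond the scatter), a modest step in which benzoyl replaces hydrogen on an aromatic carbon. That step covers the whole added group, so it cannot show how much of the rise belongs to the phenyl that now leaves.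

Compound 4 keeps the carbonyl, so it may keep part of that rise or lose part of it. With compound 1 at 5400 nM as the only reference lacking the added group, a slight drift towards lower numbers seems the better guess. The expected change is a 1.9-fold lower number from compound 3 to compound 4 (0.27 log units; within the scatter), which is not expected to clear the scatter. For compound 4 the estimated value is 16000 nM, with an expected range from 3000 nM to 60000 nM.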

Compound 4, half-maximal effective concentration: 5500 nM
Compound 4: the middle estimate sits 2.9-fold (0.46 log units) above what was measured, and the stated range covers the measured number.
By their numbers in this assay, from the lowest: compounds 1, 4 and 2 (each within the scatter of the next); then compound 3.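

Replacing phenyl with hexylamino on a carbonyl carbon gives a 5.5-fold lower number from compound 3 to compound 4 (0.74 log units; beyond the scatter) in this assay and so shows that the number at this place depends on what the carbonyl carries, not only on the carbonyl being there. The higher number seen with benzoyl therefore does not come with every carbonyl group at this place: compound 1, which lacks the added group, gives 5400 nM and compound 4 gives 5500 nM and these two values lie within the scatter of each other. No measured property of these compounds is available to explain the step.

The change removes a ring and brings in both a nitrogen and an open chain, so the compounds shown cannot tell which of these matters for the lower number. Anilino on the same carbonyl carbon would keep the ring together with a nitrogen, while a plain hexyl group would keep the chain without the nitrogen, and either could help to separate these parts of the change.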